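This account rests on a few compounds, and the source may have more. Where it says the series, first, only, none or still open, it means among the compounds named here.

Measured in a functional assay on MCF7 cells (Homo sapiens) for cytotoxicity, read by WST assay, with a stated time of 72 h; on this read-out higher numbers stand for weaker inhibition and lower numbers for stronger inhibition:
- compound 1 `COc1ccc(C2(c3ccc(O)cc3)C(=O)Nc3c2ccc(F)c3F)cc1`: 2.1 nM; 6.3 nM; > 1000 nM (3 entries)
- compound 2 `CCOc1ccc(C2(c3ccc(O)cc3)C(=O)Nc3c2ccc(F)c3F)cc1`: 11 nM
- compound 3 `O=C1Nc2c(ccc(F)c2F)C1(c1ccc(O)cc1)c1ccc(F)c(F)c1`: 7.8 nM

One entry for compound 1 is a limit of the assay and not a number, so the several entries of compound 1 in this assay, 2.1 nM; 6.3 nM; > 1000 nM (3 entries) gives no single figure for comparison. Compound 3, at 7.8 nM, cannot be separated from compound 2, since the two lie within the scatter of each other.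

The next analogue is compound 4 `O=C1Nc2c(ccc(F)c2F)C1(c1ccncc1)c1ccc(O)cc1`, which carries pyridin-4-yl in place of 3,4-difluorophenyl on a saturated ring carbon. Among the measured compounds shown here, only one measured step bears on this place, a 1.4-fold lower number from compound 2 to compound 3 (0.15 log units; within the scatter), and it stays within the scatter. For the measured compounds named here, no measured compound has a ring with a hetero atom here, so that step is only a loose guide. An estimated 2.6-fold higher number from compound 3 to compound 4 (0.41 log units; beyond the scatter) is therefore expected, a modest move towards weaker inhibition in this assay. For compound 4 the expected value is 20 nM, with an estimated range from 5 nM to 100 nM.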

Compound 4, half-maximal inhibitory concentration: 37 nM
The estimate for compound 4 lay 1.9-fold (0.27 log units) below the measured number; measured number inside the range.
By their numbers in this assay, from the lowest: compounds 3 and 2 (each within the scatter of the next); then compound 4.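

Among the compounds shown here, on the saturated ring carbon, the earlier step between two carbon-only aromatic rings had stayed within the scatter, but pyridin-4-yl gives the first step here that lies beyond it in this assay (the change is a 4.7-fold higher number from compound 3 to compound 4 (0.68 log units; beyond the scatter)). Set against the 4-ethoxyphenyl group, the same ring gives a change in the same direction, also modest and beyond the scatter (this is a 3.4-fold higher number from compound 2 to compound 4 (0.53 log units; beyond the scatter)), so among these three compounds the aromatic ring with a hetero atom stands apart from both carbon-only rings. Nothing measured here accounts for this difference.

As far as these compounds go, whether pyridin-3-yl or pyridin-2-yl at this place would read like compound 4 stays open. So does the effect of a saturated ring such as piperidine, or of a carboxylic acid on the phenyl ring.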